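The compounds below may be only part of what the source reports. "The series", "measured", "known", "first", "only" and "open" are said of these compounds alone.

Going by the values given here, in an ADME assay on HEL cells (Homo sapiens) for cytotoxicity (on this read-out higher numbers stand for lower toxicity in this test and lower numbers for higher toxicity in this test), compound 1 (`C/C=C/c1ccccc1-c1cc2cn([C@H]3C[C@H](O)[C@@H](CO)O3)c(=O)nc2o1`) gives 103000 nM, the only actual number so far. Compound 2 (`C/C=C/c1ccc(-c2cc3cn([C@H]4C[C@H](O)[C@@H](CO)O4)c(=O)nc3o2)cc1`) gives > 200000 nM, which is a limit of the assay and not a number. Compound 3 (`CCC/C=C/c1ccccc1-c1cc2cn([C@H]3C[C@H](O)[C@@H](CO)O3)c(=O)nc2o1`) differs from compound 1 by ethyl in place of hydrogen on a saturated chain carbon bound to a double-bonded chain carbon: prop-1-en-1-yl becomes pent-1-en-1-yl. Among the compounds with values here, no measured step changes this chain. The only one, an at least 1.9-fold higher number from compound 1 to compound 2 (0.28 log units; that floor lies within the scatter), concerns the aromatic group that carries the chain, leaves the chain itself unchanged and bears on this change only weakly. Within the data shown here, with that step as the sole guide, no shift beyond the scatter is expected in this assay, and the direction remains open. The expected step is a 1.1-fold lower number from compound 1 to compound 3 (0.06 log units; within the scatter). For compound 3 the estimated value is 90000 nM, with an expected range of 35000 nM to 200000 nM.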

Compound 3, half-maximal cytotoxic concentration: 41000 nM
Beside the measured number, compound 3's estimate is 2.2-fold (0.34 log units) above it; low and high end bracket the measured number.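

In this assay, going by these compounds alone, the chain gives the first step that lies beyond the scatter: prop-1-en-1-yl to pent-1-en-1-yl, with ethyl in place of hydrogen on a saturated chain carbon bound to a double-bonded chain carbon, gives a 2.5-fold lower number from compound 1 to compound 3 (0.40 log units; beyond the scatter). This position therefore responds to chain length, and here the longer chain goes with higher toxicity in this test. Nothing at hand gives a cause for this step.

Going by these compounds, whether a longer chain such as hept-1-en-1-yl lowers the number further, or a carboxylic acid at the chain end reverses the direction, remains open. On these data alone, compound 2 gives > 200000 nM, a limit and not a number, and how pent-1-en-1-yl behaves on its aromatic group also remains open.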